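Vinyl in place of the aryl group on the shared core

The source may report more compounds than this note shows. Statements on the series, on what has been measured and on what is new or still open speak of the compounds shown alone.

Working notes on a small series sharing one core. Compound 1 `Fc1ccc(-c2nc(-c3c[nH]c4ccccc34)co2)cc1` gives 40600 nM in a functional assay on MIA PaCa-2 cells (Homo sapiens) for cytotoxicity, read by MTT assay, with a stated time of 48 h; a lower number here means a stronger inhibitor, a higher number a weaker inhibitor. Compound 2 `c1ccc2c(-c3coc(-c4ccncc4)n3)c[nH]c2c1` gives 38400 nM in the same this assay, and compound 3 `COc1ccc(-c2nc(-c3c[nH]c4ccccc34)co2)cc1` gives 35000 nM. For the measured compounds named here, the three numbers sit together: the step of a 1.1-fold lower number from compound 1 to compound 2 (0.02 log units; within the scatter) and the step of a 1.2-fold lower number from compound 1 to compound 3 (0.06 log units; within the scatter) are both small, and compound 2 and compound 3 are likewise within the scatter of each other, so no compound can be set apart from the others on these numbers.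

Compound 4 `C=Cc1nc(-c2c[nH]c3ccccc23)co1` is not yet measured. Relative to compound 2 the change is vinyl in place of pyridin-4-yl on an aromatic carbon. The two measured steps bear on it only loosely: each swaps one six-membered aromatic group for another at the same place, and each stayed within the scatter. Neither removes the ring altogether, as the step to compound 4 does, so the measured steps give no direct guide to its size. Given that every aryl variant so far gave a closely similar number, the working expectation is a modest step toward a weaker inhibitor, a 1.4-fold higher number from compound 2 to compound 4 (0.16 log units; within the scatter), with a fair chance that only a limit is reported. For compound 4 the estimate in this assay is 55000 nM, ranging from 20000 nM to 160000 nM.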

Compound 4, half-maximal inhibitory concentration: 37600 nM
For compound 4 the middle estimate is 1.5-fold (0.17 log units) above the measured one; the measured number falls inside the stated range.
By their numbers in this assay, from the lowest: compounds 3, 4, 2 and 1 (each within the scatter of the next).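

In this assay, for the compounds shown here, the earlier steps only exchanged one six-membered aromatic group for another, whereas vinyl leaves no ring at all on this aromatic carbon, next to the ring nitrogen and next to the ring oxygen, and the number does not separate from those of the aryl compounds (a 1.0-fold lower number from compound 2 to compound 4 (0.01 log units; within the scatter); a 1.1-fold lower number from compound 1 to compound 4 (0.03 log units; within the scatter)). Among the four compounds, then, a ring at this place is not required for the number to stay where it is, and the change from pyridin-4-yl or 4-fluorophenyl to the much smaller vinyl group is no more visible than the exchanges between aryl groups, with no compound going against this. Nothing measured alongside these numbers bears on why this position responds so little.

As far as these compounds go, whether an amine, a carboxylic acid or a longer alkyl chain on this aromatic carbon would give a number set apart from these four remains open. From the compounds shown here alone, all four compounds differ only at this one place, so what a change elsewhere on the shared core would do also remains open.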